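Bromo substitution on the compound 2 core: cytotoxicity outlook

The compounds below may be only part of what the source reports. "The series", "measured", "known", "first", "only" and "open" are said of these compounds alone.

Measured so far in an ADME assay on MDCK cells (Canis lupus familiaris) for cytotoxicity, read by microscopy, with a stated time of 3 days; on this read-out lower numbers stand for higher toxicity in this test and higher numbers for lower toxicity in this test:
- compound 1 `NC(=O)c1nccn([C@@H]2O[C@H](CO)[C@@H](O)[C@H]2O)c1=O` gives > 250000 nM, a limit of the assay.
- compound 2 `NC(=O)c1nccnc1O` gives > 250000 nM, likewise a limit of the assay.
- compound 3 `CCCCCCCCCC(=O)Oc1ccc(COP(=O)(OCc2ccc(OC(=O)CCCCCCCCC)cc2)OP(=O)(O)OP(=O)(O)OC[C@H]2O[C@@H](n3ccnc(C(N)=O)c3=O)[C@H](O)[C@@H]2O)cc1` gives 13000 nM.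

Compound 2 therefore stands at the upper bound of what this assay reports, without a measured number; it shares this position with compound 1, as told by the limit of > 250000 nM in this assay, at which 2 of the 3 values shown sit. Within the data shown here, only compound 3 returns an actual number, and no step between compounds differing in one place has been measured, so the set gives no measured change to lean on.

Compound 4 `NC(=O)c1nc(Br)cnc1O` differs from compound 2 by bromo in place of hydrogen on an aromatic carbon.

For compound 4 the step of an at least 1.2-fold lower number from compound 2 to compound 4 (0.09 log units; that floor lies within the scatter) is expected to be none beyond the usual scatter, with compound 2 sitting at the limit of this assay as the only anchor. The estimate for compound 4 in this assay is 200000 nM, in the range 60000 nM to 300000 nM, with a fair chance that the assay again reports only a limit.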

Compound 4, minimum cytotoxic concentration: > 250000 nM
Compound 4: only a limit was reported; the forecaster's own chance of this, stated with the estimate: 70%; at least 1.2-fold (0.09 log units) between middle value and limit.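

No step can be read between compound 2 and compound 4 in this assay, because both give a limit and not a number: the limit of > 250000 nM in this assay, at which 3 of the 4 values shown sit. Going by these compounds, whether bromo in place of hydrogen on an aromatic carbon shifts the minimum cytotoxic concentration at all, and how far, stays open.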